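A Second Ring Swap on the Sulfonamide Nitrogen

This account rests on a few compounds, and the source may have more. Where it says the series, first, only, none or still open, it means among the compounds named here.

Measured compounds:
- compound 1 `Cc1cc(NS(=O)(=O)c2ccc(Nc3nncc4ccccc34)cc2)no1`: 43 nM
- compound 2 `O=S(=O)(Nc1ccccn1)c1ccc(Nc2nncc3ccccc23)cc1`: 44 nM
- compound 3 `C(=C/c1ccccc1)\C(=N\Nc1nncc2ccccc12)c1ccccc1`: 2.4 nM

All three were tested in a functional assay on COLO 205 cells (Homo sapiens) for antiproliferative activity, read by sulforhodamine B assay, with a stated time of 72 h; a higher number here means a weaker inhibitor, a lower number a stronger inhibitor. Compound 2 gives the highest of the three numbers, but it sits right beside compound 1, whose value is within the scatter of it; compound 3 lies much further off, with a number well below that of compound 2, a gap that is beyond the scatter.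

The next compound, compound 4 `Cc1cc(C)nc(NS(=O)(=O)c2ccc(Nc3nncc4ccccc34)cc2)n1`, is reached from compound 2 by one change: 4,6-dimethylpyrimidin-2-yl in place of pyridin-2-yl on a sulfonamide nitrogen. For the measured compounds named here, only one measured step bears on this kind of change, the swap of the ring on the sulfonamide nitrogen from compound 1 to compound 2, which gave a 1.0-fold higher number from compound 1 to compound 2 (0.01 log units; within the scatter). That step left the number essentially unchanged, so a further exchange of the ring at the same place is expected to move the number little, if at all, beyond the scatter, in no particular direction.

Compound 4 is therefore estimated at 45 nM, within a range of 18 nM to 110 nM, which corresponds to an expected step of a 1.0-fold higher number from compound 2 to compound 4 (0.01 log units; within the scatter).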

Compound 4, half-maximal inhibitory concentration: 7.9 nM
Compound 4: the middle estimate sits 5.7-fold (0.76 log units) above what was measured; measured number outside the range, below it.
By their numbers in this assay, from the lowest: compound 3; then compound 4; then compounds 1 and 2 (each within the scatter of the next).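

The ring on the sulfonamide nitrogen can matter in this assay: 4,6-dimethylpyrimidin-2-yl in place of pyridin-2-yl gives a 5.6-fold lower number from compound 2 to compound 4 (0.75 log units; beyond the scatter) and, in place of 5-methyl-1,2-oxazol-3-yl, it gives a 5.4-fold lower number from compound 1 to compound 4 (0.74 log units; beyond the scatter). The earlier exchange at this place, a 1.0-fold higher number from compound 1 to compound 2 (0.01 log units; within the scatter), therefore did not show that every ring here gives much the same number; one exchange at a position can stay within the scatter while another goes beyond it. Nothing available explains why this ring stands apart from the other two.

The entering ring differs from pyridin-2-yl both in its second ring nitrogen and in its two methyl groups, and the compounds shown do not separate these two differences. Plain pyrimidin-2-yl, without the methyl groups, would be needed to separate them, and a ring carrying a carboxylic acid at this place also remains an open case.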